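A few compounds are considered here, and "the series" means these few. Any claim that something is new, unique, unknown or untested is made for them only; others in the source may bear on it.

In a functional assay on MJ cells (Homo sapiens) for antiproliferative activity, with a stated time of 48 h (on this read-out higher numbers stand for weaker inhibition and lower numbers for stronger inhibition), compound 1 `O=C1C=C[C@]2(C[C@@H](c3cccc([N+](=O)[O-])c3)O[C@@H](c3ccccc3)O2)O1` gives 370 nM. This is the lower of the two actual numbers in the set, the other coming from compound 3 `O=C1C=C[C@]2(C[C@@H](c3ccccc3)O[C@@H](c3ccccc3)O2)O1` at 1700 nM. Compound 2 `O=C1C=C[C@]2(C[C@@H](c3ccc4ccccc4c3[N+](=O)[O-])O[C@@H](c3ccc4ccccc4c3[N+](=O)[O-])O2)O1` gives > 20000 nM, which is a limit of the assay and not a number.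

The next compound to consider is compound 4 `O=C1C=C[C@]2(C[C@@H](c3cccc([N+](=O)[O-])c3)O[C@@H](c3cccc([N+](=O)[O-])c3)O2)O1`, in which the remaining phenyl of compound 1 becomes 3-nitrophenyl. The change is nitro in place of hydrogen on an aromatic carbon.

For the measured compounds named here, one measured step bears directly on this. Replacing the nitro of compound 1 with hydrogen gives a 4.6-fold higher number from compound 1 to compound 3 (0.66 log units; beyond the scatter), so a nitro group on the other aromatic ring went with a lower number. That step is modest, and it was measured at a different place in the molecule, so it can only be a loose guide. Compound 2 also carries two nitro groups, but its aromatic groups differ as well, so no clean step can be read from it. It is still a reason to keep the upper end of the range wide.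

A small shift toward stronger inhibition is expected, and the estimated change is a 1.5-fold lower number from compound 1 to compound 4 (0.17 log units; within the scatter). For compound 4 the estimated value is 250 nM, with an expected range from 70 nM to 1200 nM.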

Compound 4, half-maximal inhibitory concentration: 170 nM
For compound 4 the middle estimate is 1.5-fold (0.17 log units) above the measured one, and the stated range covers the measured number.
By their numbers in this assay, from the lowest: compound 4; then compound 1; then compound 3. At a limit, above all of these: compound 2.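

In this assay, turning the remaining phenyl of compound 1 into 3-nitrophenyl gives a lower number (a 2.2-fold lower number from compound 1 to compound 4 (0.34 log units; beyond the scatter)), a step that is modest but beyond the scatter. For the compounds shown here, until now, the only nitro step available was on the other aromatic ring (a 4.6-fold higher number from compound 1 to compound 3 (0.66 log units; beyond the scatter)), so this is the first sign that a nitro group at this second place also goes with stronger inhibition. Compound 4 carries a nitro group on both rings and has the lowest number among the compounds with actual values, so in this small set the second nitro group did not cancel the benefit seen with the first. Compound 2 also has two nitro groups, but it differs from compound 4 in more than one place, so it is not part of this comparison. Compound 2 gives > 20000 nM, which is a limit of the assay.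

The compounds shown leave open whether nitro itself matters at this place on the ring, or whether another group, such as a nitrile, an amine or a carboxylic acid, would give a similar number. No measurement here accounts for why the nitro group goes with a lower number.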